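The source may report more compounds than this note shows. Statements on the series, on what has been measured and on what is new or still open speak of the compounds shown alone.

The measured compounds, with their values in an assay on HEK293 cells for inhibition of N-acylethanolamine-hydrolyzing acid amidase (Rattus norvegicus), read by LC-MS, with a stated time of 30 min; on this read-out higher numbers stand for weaker inhibition and lower numbers for stronger inhibition:

Compound 1 `O=C(CCCCCCc1cccc(F)c1)N1CCCC1`: 7300 nM
Compound 2 `O=C(CCc1ccc(-c2ccccc2F)cc1)N1CCCC1`: 2800 nM
Compound 3 `COc1ccc(CCCCCCC(=O)N2CCCC2)cc1`: 35400 nM

Among these three, compound 2 has the lowest number in this assay. Its nearest neighbour is compound 1, whose number is higher by a margin beyond the usual scatter, and the furthest is compound 3, whose number is higher still, well beyond the scatter. None of these three pairs differs in only one place, so no single structural step can be read off from the measured set.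

Compound 4 `O=C(CCc1ccc(-c2cccs2)cc1)N1CCCC1` has not yet been measured. It differs from compound 2 in one place: thiophen-2-yl in place of 2-fluorophenyl on an aromatic carbon. Among the compounds with values here, no measured pair shows what such an exchange does in this assay, so the step from compound 2 to compound 4 cannot be taken from the data and rests on the value of compound 2 alone. Because compound 2 gives 2800 nM in this assay, the author expects compound 4 to land near it, with at most a modest shift toward a higher number that may well stay within the scatter; the expected step is a 1.4-fold higher number from compound 2 to compound 4 (0.15 log units; within the scatter). Compound 4 is therefore estimated at 4000 nM, with a range from 1500 nM to 12000 nM.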

Compound 4, half-maximal inhibitory concentration: > 100000 nM
Compound 4: no number, only a limit; the forecaster's own chance of this, stated with the estimate: 5%; at least 25-fold (1.39 log units) between middle value and limit.
By their numbers in this assay, from the lowest: compound 2; then compound 1; then compound 3. At a limit, above all of these: compound 4.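

In this assay, within the data shown here, thiophen-2-yl in place of 2-fluorophenyl on this aromatic carbon, para to a group of 9 heavy atoms, gives an at least 35-fold higher number from compound 2 to compound 4 (1.55 log units; beyond the scatter), the first step in this set that can be read at a single place. The result for compound 4 is a limit of the assay and not a number: the limit of > 100000 nM in this assay, at which 1 of the 4 values shown sits. The step shows that the two aromatic groups are not interchangeable at this position, and that this one exchange on the shared core is enough to carry the read-out in this assay from a measured value to that limit.

The compounds shown leave open which part of the exchange goes with this large step, the loss of the fluorine or the change from the six-membered carbon ring to the five-membered ring with its sulfur. Among these compounds, an unsubstituted phenyl, a thiophen-3-yl or a pyridin-2-yl group on the same aromatic carbon would help to separate these, and the single pair gives no sign of how any of them would read.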